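Working notes on the shared core: compound 2 to compound 4

The source may hold more compounds than are shown below. What is called first, only, known or untested is meant among the compounds shown, and "the series" means these compounds.

Three compounds of the shared core have been run in a functional assay on Hs 683 cells (Homo sapiens) for inhibition, read by MTT assay, with a stated time of 72 h; on this read-out higher numbers stand for weaker inhibition of growth and lower numbers for stronger inhibition of growth. Compound 1 `Cc1onc(-c2c(F)cccc2Cl)c1C(=O)Nc1c(-c2ccccc2)[nH]c2ccccc12` gives 15000 nM in this assay. Compound 2 `O=C(COc1ccc(Cl)cc1)Nc1c(-c2ccccc2)[nH]c2ccccc12` gives 38000 nM in this assay. Compound 3 `CCN(CC)C(=S)Sc1c(-c2ccc(Br)cc2)[nH]c2ccc(Br)cc12` gives 22000 nM in this assay. Compound 2 stands with the highest number of the three; against compound 3 the gap lies within the scatter, so no order between those two is claimed, while against compound 1 the gap lies beyond the scatter, compound 1 showing the lower number. For the measured compounds named here, no pair of measured compounds differs in a single place, so no measured step is available as a guide.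

Compound 4 `O=C(CSCc1ccccc1)Nc1c(-c2ccccc2)[nH]c2ccccc12` is the next compound for this assay. It differs from compound 2 in one place: benzylsulfanyl in place of 4-chlorophenoxy on a saturated chain carbon bound to a carbonyl carbon. Going by the values given here, the change keeps the count of heavy atoms, rings, donors and acceptors and no measured analogue speaks to it; the expected step is no change at the digits printed from compound 2 to compound 4 (within the scatter), none beyond the scatter in either direction. Compound 4 is therefore estimated at 38000 nM in this assay, with a range from 12000 nM to 100000 nM.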

Compound 4, concentration for 50% growth inhibition: 33000 nM
Beside the measured number, compound 4's estimate is 1.2-fold (0.06 log units) above it, and the stated range covers the measured number.
By their numbers in this assay, from the lowest: compounds 1, 3, 4 and 2 (each within the scatter of the next, the first and the last beyond it).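

In this assay, for the compounds shown here, benzylsulfanyl in place of 4-chlorophenoxy on a saturated chain carbon bound to a carbonyl carbon gives a 1.2-fold lower number from compound 2 to compound 4 (0.06 log units; within the scatter), the first single-place step, and it lies within the scatter. At this position, then, one aromatic group of the same heavy-atom count replaces another, with sulfur and a methylene entering and oxygen and chlorine leaving, and no difference in growth inhibition can be claimed. No accompanying measurement bears on this result.

Going by these compounds alone, whether any group at this position can move the number beyond the scatter remains open, as this single step covers only two neutral aromatic groups. An amine, a carboxylic acid or a longer chain carrying the benzylsulfanyl group would test that directly.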